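Fluoro substitution in a cytotoxicity series: working notes

This account rests on a few compounds, and the source may have more. Where it says the series, first, only, none or still open, it means among the compounds named here.

Measured in a functional assay on MDA-MB-231 cells (Homo sapiens) for cytotoxicity, read by MTT assay, with a stated time of 72 h; on this read-out higher numbers stand for weaker inhibition and lower numbers for stronger inhibition:
compound 1 `COc1cc2c(Oc3ccc(NC(=O)c4nn(-c5ccccc5)c(=O)c5ccccc45)cc3F)ccnc2cc1OCCCN1CCN(C)CC1` gives 1580 nM;
compound 2 `COc1cc2c(Oc3ccc(NC(=O)c4nn(-c5ccc(F)cc5)c(=O)c5ccccc45)cc3F)ccnc2cc1OCCCN1CCN(C)CC1` gives 460 nM;
compound 3 `COc1cc2c(Oc3ccc(NC(=O)c4nn(-c5ccccc5)c(=O)c5ccccc45)cc3F)ccnc2cc1OCCCN1CCCCC1` gives 1880 nM.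

Compound 2 differs from compound 1 by fluoro in place of hydrogen on an aromatic carbon, and this gave a 3.4-fold lower number from compound 1 to compound 2 (0.54 log units; beyond the scatter). Compound 3 differs from compound 1 by piperidin-1-yl in place of 4-methylpiperazin-1-yl on a saturated chain carbon, three bonds along the chain from an oxygen on an aromatic ring; here a 1.2-fold higher number from compound 1 to compound 3 (0.08 log units; within the scatter), so the two cores behave alike in this assay.

Compound 4 `COc1cc2c(Oc3ccc(NC(=O)c4nn(-c5ccccc5F)c(=O)c5ccccc45)cc3F)ccnc2cc1OCCCN1CCCCC1` is not yet measured. It differs from compound 3 by fluoro in place of hydrogen on an aromatic carbon. This is the same kind of change as that from compound 1 to compound 2, but the place differs: ortho to a large group rather than para to a large group. Among the compounds with values here, the step is expected to run the same way, a 2.5-fold lower number from compound 3 to compound 4 (0.40 log units; beyond the scatter), with less confidence because the only measured instance, a 3.4-fold lower number from compound 1 to compound 2 (0.54 log units; beyond the scatter), sits at a different place. Compound 4 is therefore estimated at 750 nM in this assay, expected between 300 nM and 2200 nM.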

Compound 4, half-maximal inhibitory concentration: 910 nM
Compound 4: middle estimate off by 1.2-fold (0.08 log units), on the low side, within the range that was stated.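

In this assay, fluoro in place of hydrogen again gives a lower number, a 2.1-fold lower number from compound 3 to compound 4 (0.32 log units; beyond the scatter), and the two steps run the same way without a size difference beyond the scatter: the same change on two cores in this assay, a 3.4-fold lower number (0.54 log units; beyond the scatter) from compound 1 to compound 2 and a 2.1-fold lower number (0.32 log units; beyond the scatter) from compound 3 to compound 4, 1.7-fold (0.22 log units) apart, within the scatter of two such steps

So, in these two pairs, the change carries from the core of compound 1 to the core of compound 3. This does not show that the step is independent of core, as core and place vary together: the fluoro of compound 4 is ortho to a large group, whereas that of compound 2 sits elsewhere.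

The compounds shown leave open how the two fluoro places compare on a single core. They also leave open whether chloro or methoxy on the same phenyl ring would give a similar step.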